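The source may report more compounds than this note shows. Statements on the series, on what has been measured and on what is new or still open speak of the compounds shown alone.

Compound 1 `Oc1ccc(-c2cc(-c3ccccc3F)cc(-c3cccc(O)c3)n2)cc1` — in a functional assay on HeLa cells (Homo sapiens) for inhibition (a lower number here means a stronger inhibitor, a higher number a weaker inhibitor), compound 1 gives 14300 nM.
Compound 2 `Oc1ccc(-c2cc(-c3ccccc3F)cc(-c3ccc(O)cc3)n2)cc1` — compound 2 gives > 50000 nM.

The value of compound 2 is a limit of the assay, not a number, as the limit of > 50000 nM in this assay, at which 1 of the 2 values shown sits, shows. Compound 2 therefore stands at the weak end of the two measured values, and the step of an at least 3.4-fold higher number from compound 1 to compound 2 (0.54 log units; beyond the scatter) shows how it got there. Compound 3 `Oc1ccc(-c2cc(-c3ccc(F)cc3)cc(-c3ccc(O)cc3)n2)cc1` keeps the core of compound 2 and differs only in 4-fluorophenyl in place of 2-fluorophenyl on an aromatic carbon. Within the data shown here, the one measured step concerns the hydroxyphenyl groups, not the fluorophenyl group, so nothing measured here bears directly on this change, and its size cannot be read from the data. Starting from a limit, the step that the limit leaves unreadable from compound 2 to compound 3 is expected to stay near the limit, with a fair chance that only a limit is reported again. Compound 3 is thus estimated at 60000 nM, within 15000 nM to 200000 nM.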

Compound 3, half-maximal inhibitory concentration: 8680 nM
Estimate against measurement, compound 3: 6.9-fold (0.84 log units) above; the measured number lies below the stated range.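

The fluorophenyl group opposite the ring nitrogen turns out to matter in its own right. In this assay, 4-fluorophenyl in place of 2-fluorophenyl gives an at least 5.7-fold lower number from compound 2 to compound 3 (0.76 log units; beyond the scatter), although the two groups hold the same atoms and only the place of the fluorine differs. The full size of this step cannot be given because the value of compound 2 is a limit of the assay and not a number: the limit of > 50000 nM in this assay, at which 1 of the 3 values shown sits.

From the compounds shown here alone, whether 4-fluorophenyl would bring a similar change alongside the 3-hydroxyphenyl group of compound 1 stays open. Going by these compounds, it is also open whether the fluorine itself is needed, a question that a plain phenyl, 4-chlorophenyl or 4-methoxyphenyl group at this position could answer.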